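From acetoxy to (diethylcarbamoyl)oxy on the shared core

The source may report more compounds than this note shows. Statements on the series, on what has been measured and on what is new or still open speak of the compounds shown alone.

Among the measured compounds shown here, in a functional assay on NIH3T3 cells (Mus musculus) for cytotoxicity, read by MTT assay, with a stated time of 48 h (a higher number here means a weaker inhibitor, a lower number a stronger inhibitor), compound 1 `CC(=O)OC1=C(c2cccc3cccnc23)Oc2cc3ccccc3cc2-n2cccc21` gives 68 nM and compound 2 `CC(=O)OC1=C(c2cc(C)nc3ccccc23)Oc2cc3ccccc3cc2-n2cccc21` gives 278 nM, the higher of the two numbers measured so far. Compound 3 `CCN(CC)C(=O)OC1=C(c2cc(C)nc3ccccc23)Oc2cc3ccccc3cc2-n2cccc21` differs from compound 2 in one place, with diethylamino in place of methyl on a carbonyl carbon, which turns acetoxy into (diethylcarbamoyl)oxy. For the measured compounds named here, no measured step touches this carbonyl carbon. Going by the values given here, the only step available is a 4.1-fold higher number from compound 1 to compound 2 (0.61 log units; beyond the scatter), and it changes a different group, on a double-bonded ring carbon. It bears on the question only indirectly, showing that one change on this core can move the number beyond the scatter. A modest rise in this assay is therefore tentatively expected, with the expected step being a 2.2-fold higher number from compound 2 to compound 3 (0.33 log units; beyond the scatter). Compound 3 is estimated at 600 nM, within an expected range from 170 nM to 2000 nM.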

Compound 3, half-maximal inhibitory concentration: 9000 nM
Beside the measured number, compound 3's estimate is 15-fold (1.18 log units) below it; measured number above the stated range.
By their numbers in this assay, from the lowest: compound 1; then compound 2; then compound 3.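

In this assay the carbonyl carbon turns out to be a sensitive place on the shared core: diethylamino in place of methyl, which turns acetoxy into (diethylcarbamoyl)oxy, gives a 32-fold higher number from compound 2 to compound 3 (1.51 log units; beyond the scatter) and is a large step. Among the compounds shown here, the only earlier step, a 4.1-fold higher number from compound 1 to compound 2 (0.61 log units; beyond the scatter) on a double-bonded ring carbon, was modest, so this is the first sign that the group on the carbonyl carbon can shift the number much further than that exchange did. Nothing measured here says why the number rises so far.

On these data alone, whether an amine such as dimethylamino, or an ethyl chain in place of methyl, on this carbonyl carbon would give a step of similar size remains open. Also open, as far as these compounds go, is whether the same exchange would move the number as far with the quinolin-8-yl group of compound 1 on the double-bonded ring carbon.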